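A few compounds are considered here, and "the series" means these few. Any claim that something is new, unique, unknown or untested is made for them only; others in the source may bear on it.

Compound 1 `Cc1ccc(N2CCN(C(=O)Nc3ccc(C(C)C)cc3)CC2)nn1` opens the set. In an assay on HEK293 cells for inhibition of transient receptor potential cation channel subfamily V member 1 (Homo sapiens), read by FLIPR (on this read-out higher numbers stand for weaker inhibition and lower numbers for stronger inhibition), compound 1 gives only a limit, > 10000 nM. Compound 2 `Cc1ccc(N2CCN(C(=O)Nc3ccc(C(F)(F)F)cc3)CC2)nn1` differs from compound 1 by trifluoromethyl in place of isopropyl on an aromatic carbon. In this assay compound 2 likewise gives only a limit, > 10000 nM. The step that the two limits leave unreadable from compound 1 to compound 2 therefore cannot be sized. Compound 3 `CC(C)c1ccc(NC(=O)N2CCN(c3ccc(-c4ccccc4)nn3)CC2)cc1` differs from compound 1 in the core, where (phenyl in place of methyl on an aromatic carbon). In this assay compound 3 too gives only a limit, > 10000 nM. The step that the two limits leave unreadable from compound 1 to compound 3 is equally unreadable. Within the data shown here, what the three measured compounds share is the limit of > 10000 nM in this assay, at which 3 of the 3 values shown sit, so no step among them can be read, and nothing separates the isopropyl from the trifluoromethyl, or the methyl core from the phenyl core, on this read-out.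

Compound 4 `O=C(Nc1ccc(C(F)(F)F)cc1)N1CCN(c2ccc(-c3ccccc3)nn2)CC1` has not yet been measured in this assay. It differs from compound 3 by trifluoromethyl in place of isopropyl on an aromatic carbon, which is the same change as that made from compound 1 to compound 2, now carried out on the core of compound 3. That change left compound 1 and compound 2 together at the limit, and compound 3 sits at the same limit, so there is no readable movement on which to build. The step that the limit leaves unreadable from compound 3 to compound 4 is accordingly expected to be small. Compound 4 is expected to come out near 20000 nM. For compound 4 the expected range runs from 5000 nM to 100000 nM, with a limit rather than a number the most likely outcome.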

Compound 4, half-maximal inhibitory concentration: > 10000 nM
Compound 4 gave a limit, no number (the forecaster's own chance of this, stated with the estimate: 85%); the middle value lies beyond the limit too.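

In this assay compound 4 gives only a limit, > 10000 nM. Neither the step from compound 3 to compound 4 nor the step from compound 2 to compound 4 can be read, and the whole set rests on one entry: the limit of > 10000 nM in this assay, at which 4 of the 4 values shown sit. The compounds shown leave open whether trifluoromethyl in place of isopropyl, or phenyl in place of methyl, changes inhibition at all.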